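The source may hold more compounds than are shown below. What is called first, only, known or untested is meant among the compounds shown, and "the series" means these compounds.

Measured compounds: compound 1 `COc1cc(CNC(=S)NC(CCc2ccc(C(C)(C)C)cc2)COC(=O)C(C)(C)C)ccc1O` with 36.5 nM; compound 2 `COc1cc(CNC(=S)NCC(COC(=O)C(C)(C)C)Cc2ccc(C(C)(C)C)cc2)cc(Cl)c1O` with 21.3 nM; compound 3 `COc1cc(CNC(=S)NCC(COC(=O)C(C)(C)C)Cc2ccc(C)c(C)c2)cc(Cl)c1O` with 30.9 nM.

In an assay on CHO cells for displacement of a labelled ligand from transient receptor potential cation channel subfamily V member 1 (Rattus norvegicus) (on this read-out higher numbers stand for weaker inhibition and lower numbers for stronger inhibition), compound 1 gives the highest of the three numbers, but its distances to compound 3 and to compound 2 are both within the scatter, so the three stand together. Among the measured compounds shown here, the one counted step, a 1.5-fold higher number from compound 2 to compound 3 (0.16 log units; within the scatter), concerns the other end of the molecule and says nothing about the change at hand. Compound 4 `COc1cc(CNC(=S)NC(CCc2ccc(C(C)(C)C)cc2)COC(=O)C(C)(C)C)cc(I)c1O` differs from compound 1 by iodo in place of hydrogen on an aromatic carbon. For the measured compounds named here, compounds 2 and 3 carry a chloro at that position, yet they also differ from compound 1 elsewhere, so no direct step exists. The author therefore expects little movement, a 1.5-fold lower number from compound 1 to compound 4 (0.16 log units; within the scatter), and estimates for compound 4 25 nM, between 8 nM and 80 nM.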

Compound 4, inhibition constant: 214 nM
Beside the measured number, compound 4's estimate is 8.6-fold (0.93 log units) below it; the whole stated range lies below it.
By their numbers in this assay, from the lowest: compounds 2, 3 and 1 (each within the scatter of the next); then compound 4.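

In this assay, among the compounds shown here, iodo on the aromatic carbon ortho to a hydroxy group gives a 5.9-fold higher number from compound 1 to compound 4 (0.77 log units; beyond the scatter), the first direct step at this position, and it goes towards weaker inhibition. So this carbon of the core of compound 1 is not indifferent to substitution, which compounds 2 and 3, differing from compound 1 elsewhere as well, could not show. Nothing shown here accounts for this step.

Going by these compounds, whether fluoro, bromo or a methyl group on this carbon would shift the number as iodo does remains open. Also open, on these data alone, is what chloro alone does here, since compounds 2 and 3 offer no direct comparison with compound 1.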